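Swapping fluoro for trifluoromethyl: what to expect for toxicity

The source may report more compounds than this note shows. Statements on the series, on what has been measured and on what is new or still open speak of the compounds shown alone.

Compound 1 `Cc1ccccc1C(=O)n1c(-c2cn(-c3ccccc3)nc2-c2ccc(F)cc2)nc2ccccc21` is the anchor of this short series. In an ADME assay on HEK-293T cells (Homo sapiens) for cytotoxicity, read by MTT assay, with a stated time of 24 h (on this read-out higher numbers stand for lower toxicity in this test and lower numbers for higher toxicity in this test), compound 1 gives 189000 nM, the highest of the two numbers recorded so far. Going by the values given here, its only measured neighbour, compound 2 `Cc1cncc(C(=O)n2c(-c3cn(-c4ccccc4)nc3-c3ccc(F)cc3)nc3ccccc32)c1`, gives 119000 nM in this assay, and the step of a 1.6-fold lower number from compound 1 to compound 2 (0.20 log units; within the scatter) is too small to count as a real difference. That step replaces the group on the carbonyl carbon, so it says nothing directly about the change now under study.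

Compound 3 `Cc1ccccc1C(=O)n1c(-c2cn(-c3ccccc3)nc2-c2ccc(C(F)(F)F)cc2)nc2ccccc21` differs from compound 1 by trifluoromethyl in place of fluoro on an aromatic carbon. Among the compounds with values here, no measured step touches this position, so the only available guide is the finding that the one change tried so far left the number essentially where it was. With nothing in the data pointing either way, no step beyond the scatter is expected here. Compound 3 is therefore estimated to give 170000 nM in this assay, with a likely range from 80000 nM to 360000 nM. The expected step is a 1.1-fold lower number from compound 1 to compound 3 (0.05 log units; within the scatter).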

Compound 3, half-maximal cytotoxic concentration: 179000 nM
Compound 3: the middle estimate sits 1.1-fold (0.02 log units) below what was measured, within the range that was stated.
By their numbers in this assay, from the lowest: compounds 2, 3 and 1 (each within the scatter of the next).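

Moving from 4-fluorophenyl to 4-(trifluoromethyl)phenyl gives a 1.1-fold lower number from compound 1 to compound 3 (0.02 log units; within the scatter) in this assay and is the first change shown at this position. The entering group has 4 heavy atoms where fluoro has 1, yet this swap on an aromatic carbon para to a large group produces no difference that can be told apart from the scatter of the test, so on this one pair the position accepts the larger of these two groups with no real shift in the toxicity reading. Nothing measured here bears on why the reading behaves this way.

Fluoro and trifluoromethyl both carry no hydrogen-bond donors or acceptors and no net charge, so it remains open whether an amine or a carboxylic acid at the same carbon would also stay within the scatter. From the compounds shown here alone, it is also open whether the swap to trifluoromethyl would read the same when the 5-methylpyridin-3-yl group of compound 2 sits on the carbonyl carbon in place of the 2-methylphenyl group.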